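The source may report more compounds than this note shows. Statements on the series, on what has been measured and on what is new or still open speak of the compounds shown alone.

- compound 1 `COc1cc(N2CCN(C(=O)N3CCN(C)CC3)CC2)ccc1Nc1nc(NC2CCCCC2)c2nc[nH]c2n1`: 75000 nM
- compound 2 `COc1cc(N2CCN(C(=O)N3CCC(O)C3)CC2)ccc1Nc1nc(NC2CCCCC2)c2nc[nH]c2n1`: 19000 nM
- compound 3 `COc1cc(N2CCC(C(=O)N3CCC(N(C)C)C3)CC2)ccc1Nc1nc(NC2CCCCC2)c2nc[nH]c2n1`: 38000 nM

All three values come from a physicochemical assay for solubility, measured as kinetic solubility, at pH 7.4; a higher number here means a more soluble compound, a lower number a less soluble compound. Compound 3, at 38000 nM, sits within the usual scatter of both compound 1 and compound 2, so it cannot be ranked against either.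

The next compound to be tested is compound 4 `CCN(CC)CC1CCN(c2ccc(Nc3nc(NC4CCCCC4)c4nc[nH]c4n3)c(OC)c2)CC1`. It carries (diethylamino)methyl in place of (3-(dimethylamino)pyrrolidin-1-yl)carbonyl on a saturated ring carbon.

Within the data shown here, only one measured step offers a guide: a 3.9-fold lower number from compound 1 to compound 2 (0.60 log units; beyond the scatter). That modest step, beyond the scatter, exchanged 4-methylpiperazin-1-yl for 3-hydroxypyrrolidin-1-yl on a carbonyl carbon. Among the measured compounds shown here, it is only a loose parallel, since compound 4 has no such carbonyl and no measured step shows what removing one does. A change in one group did move this assay modestly, so a step of similar size is possible, but the data give no firm direction. The expected step, leaning slightly downward and within the scatter, is a 1.3-fold lower number from compound 3 to compound 4 (0.10 log units; within the scatter). The estimate for compound 4 is 30000 nM, with an expected range of 10000 nM to 80000 nM.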

Compound 4, solubility: 19000 nM
For compound 4 the middle estimate is 1.6-fold (0.20 log units) above the measured one; the range from low to high includes it.
By their numbers in this assay, from the lowest: compounds 2, 4, 3 and 1 (each within the scatter of the next, the first and the last beyond it).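

On the saturated ring carbon of the six-membered ring, (diethylamino)methyl in place of (3-(dimethylamino)pyrrolidin-1-yl)carbonyl gives a 2.0-fold lower number from compound 3 to compound 4 (0.30 log units; within the scatter) in this assay and so leaves the two compounds unranked. The earlier compounds shown here kept a carbonyl on the group they varied, whereas compound 4 shows that a reading within the scatter of compound 3 is possible with the carbonyl and the five-membered ring both gone and the group cut from 10 heavy atoms to 6. Nothing measured here accounts for how close the two readings lie.

On these data alone, the carbonyl and the ring leave together in this one step, so their separate contributions stay unknown. As far as these compounds go, how a carboxylic acid or a morpholine on that same ring carbon would read in this assay also stays open.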